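A few compounds are considered here, and "the series" means these few. Any claim that something is new, unique, unknown or untested is made for them only; others in the source may bear on it.

Compound 1 `COc1ccc(C(=O)/C=C/c2cccc(F)c2)c2c1C=CC(C)(C)O2` was tested in a functional assay on SK-OV-3 cells (Homo sapiens) for antiproliferative activity, read by MTT assay, with a stated time of 24 h (a higher number here means a weaker inhibitor, a lower number a stronger inhibitor), and gave only a limit of the assay, > 10000 nM, so no number is known for it. Compound 2 `COc1ccc(C(=O)/C=C/c2ccc(N(c3ccccc3)c3ccccc3)cc2)c2c1C=CC(C)(C)O2` likewise gave only a limit in this assay, > 10000 nM. Going by the values given here, compound 3 `COc1ccc(C(=O)/C=C/c2ccc3ccccc3n2)c2c1C=CC(C)(C)O2` is the one compound of the three with a measured number, giving 2350 nM in this assay. Compound 1 therefore stands at the weak end of what is shown, at the limit of > 10000 nM in this assay, at which 2 of the 3 values shown sit, where the second limit also sits.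

Compound 4 `COc1ccc(C(=O)/C=C/c2ccc([N+](=O)[O-])cc2)c2c1C=CC(C)(C)O2` has not yet been measured. It differs from compound 1 in one place: 4-nitrophenyl in place of 3-fluorophenyl on a double-bonded chain carbon bound to a double-bonded chain carbon. No step between two measured compounds is available that would show how such a change moves this assay; the only compound that left the limit, compound 3, carries a different ring entirely, so nothing shown connects a nitro group to a gain in activity.

With compound 1 at a limit, the expected step from compound 1 to compound 4 in this assay is an at least 1.2-fold lower number from compound 1 to compound 4 (0.09 log units; that floor lies within the scatter), which may be no more than the scatter of repeated measurements. Compound 4 is thus expected to give about 8000 nM in this assay, within a range of 2000 nM to 30000 nM, with a fair chance that only a limit is reported again.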

Compound 4, half-maximal inhibitory concentration: 3420 nM
For compound 4 the middle estimate is 2.3-fold (0.37 log units) above the measured one, and the stated range covers the measured number.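

Putting 4-nitrophenyl in place of 3-fluorophenyl, on a double-bonded chain carbon bound to a double-bonded chain carbon, gives an at least 2.9-fold lower number from compound 1 to compound 4 (0.46 log units; beyond the scatter) in this assay. Going by these compounds alone, until now the only compound with a measured number, compound 3, carried a different ring, so this result shows that a six-membered aromatic ring of carbon only can also come off the limit at this place, although compound 1 and compound 2, which also carry such rings, do not. The true size of the step remains unknown because compound 1 has only a limit and no number, which makes the step a floor: the limit of > 10000 nM in this assay, at which 2 of the 4 values shown sit.

The swap changes both the group on the ring and where it sits, so the compounds shown leave open which of the two carries the step; a 4-fluorophenyl or a 3-nitrophenyl ring would separate them. Also open, on these data alone, is how other groups at the same place, such as a 4-aminophenyl or a 4-carboxyphenyl ring, would read in this assay.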